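The compounds below may be only part of what the source reports. "The series", "measured", "known", "first", "only" and "open" are said of these compounds alone.

Measured so far in an ADME assay (liver) for metabolic stability, with Liver microsome (Rattus norvegicus) as the target, using microsomes and NADPH, with a stated time of 30 min, tested at 1 uM; a higher number here means faster removal of the compound, a lower number slower removal:
- compound 1 `Nc1ccc(S(=O)(=O)N2CCN(c3ncc(C(O)(C(F)(F)F)C(F)(F)F)cc3C#CCO)CC2)cn1` gives 65 mL.min-1.g-1
- compound 2 `Cn1cc(-c2cc(C(O)(C(F)(F)F)C(F)(F)F)cnc2N2CCN(S(=O)(=O)c3ccc(N)nc3)CC2)cn1` gives 44 mL.min-1.g-1
- compound 3 `CS(=O)(=O)Nc1cccc(-c2cc(C(O)(C(F)(F)F)C(F)(F)F)cnc2N2CCN(S(=O)(=O)c3ccc(N)nc3)CC2)c1` gives 81 mL.min-1.g-1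

On these three numbers compound 2 sits at the low end, yet the step of a 1.5-fold lower number from compound 1 to compound 2 (0.17 log units; within the scatter) and the step of a 1.8-fold higher number from compound 2 to compound 3 (0.27 log units; within the scatter) both fall within the scatter of repeated measurements, as does a 1.2-fold higher number from compound 1 to compound 3 (0.10 log units; within the scatter), so none of the three compounds can be told apart with confidence.

Compound 4 `Nc1ccc(S(=O)(=O)N2CCN(c3ncc(C(O)(C(F)(F)F)C(F)(F)F)cc3-c3ccc4c(c3)CC(=O)N4)CC2)cn1` is reached from compound 2 by a single change: a group of 10 heavy atoms (8 carbon, 1 nitrogen, 1 oxygen; one five-membered non-aromatic ring with 1 hetero atom, one six-membered aromatic ring of carbon only) in place of a group of 6 heavy atoms (4 carbon, 2 nitrogen; one five-membered aromatic ring with 2 hetero atoms), on an aromatic carbon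

Every measured step bears on this spot. The three groups tried there so far, a 3-hydroxyprop-1-yn-1-yl, a 1-methyl-1H-pyrazol-4-yl and a 3-(methanesulfonamido)phenyl, all gave numbers within the scatter of one another in this assay. The group entering compound 4 is larger than the one it replaces and carries a ring of a different kind, but nothing measured here shows such a change moving the number far in either direction. The expected step is therefore small, a 1.4-fold higher number from compound 2 to compound 4 (0.13 log units; within the scatter), and compound 4 is estimated at 60 mL.min-1.g-1, with a likely range from 30 mL.min-1.g-1 to 120 mL.min-1.g-1.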

Compound 4, intrinsic clearance in microsomes: 119 mL.min-1.g-1
Compound 4: the middle estimate sits 2.0-fold (0.30 log units) below what was measured; low and high end bracket the measured number.
By their numbers in this assay, from the lowest: compounds 2, 1, 3 and 4 (each within the scatter of the next, the first and the last beyond it).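

In this assay, this position now shows a step that clears the scatter, a 2.7-fold higher number from compound 2 to compound 4 (0.43 log units; beyond the scatter), so what sits on this aromatic carbon is not wholly without consequence, though the size of the step is modest. The entering group, with its five-membered non-aromatic ring and its six-membered aromatic ring of carbon only, still cannot be told apart from the other two groups tried here, as a 1.5-fold higher number from compound 3 to compound 4 (0.17 log units; within the scatter) and a 1.8-fold higher number from compound 1 to compound 4 (0.26 log units; within the scatter) both stay within the scatter, which means only the two ends of the series, compound 2 and compound 4, are truly separated. Nothing available here gives a measured reason for that one clear step.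

The compounds shown leave open which part of the entering group goes with the higher number, as its size, its carbonyl, its amide hydrogen and its ring types all change together in a single step. As far as these compounds go, a plain phenyl group or a morpholine on the same carbon would help to pull these features apart, and it also remains open whether any group at this position can bring the number clearly below that of compound 2.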